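A Bromo Added to Compound 2

A few compounds are considered here, and "the series" means these few. Any claim that something is new, unique, unknown or untested is made for them only; others in the source may bear on it.

Among the measured compounds shown here, in a functional assay on MDA-MB-436 cells (Homo sapiens) for antiproliferative activity, read by MTT assay, with a stated time of 24 h (a higher number here means a weaker inhibitor, a lower number a stronger inhibitor), compound 2 (`O=C(O)CC(NS(=O)(=O)c1ccccc1)c1ccc(Cl)cc1Cl`) gives 59000 nM as the only true number so far. Compound 1 (`O=C(O)CC(NS(=O)(=O)c1ccccc1Br)c1ccccc1`) gives > 100000 nM as a limit of the assay. Compound 3 (`O=C(O)CC(NS(=O)(=O)c1ccccc1Br)c1ccc(Cl)cc1Cl`) differs from compound 2 by one change, bromo in place of hydrogen on an aromatic carbon. For the measured compounds named here, no measured step yet shows what this change does. The expected step of a 1.3-fold lower number from compound 2 to compound 3 (0.12 log units; within the scatter) is small and leans towards a stronger inhibitor, if it leaves the scatter at all. Compound 3 is estimated at 45000 nM with an expected range from 15000 nM to 100000 nM in this assay.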

Compound 3, half-maximal inhibitory concentration: > 100000 nM
Compound 3 was reported as a limit; the forecaster's own chance of this, stated with the estimate: 20%; middle value at least 2.2-fold (0.34 log units) away from the limit.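

Among the compounds shown here, with bromo in place of hydrogen on an aromatic carbon, ortho to a large group, the first step at this position reads an at least 1.6-fold higher number from compound 2 to compound 3 (0.22 log units; that floor lies within the scatter) in this assay. Compound 3 stands at a limit, so this step gives only a floor, and it shows no gain in strength from the bromo. The step between compound 1 and compound 3 cannot be read, and the same limit returns: the limit of > 100000 nM in this assay, at which 2 of the 3 values shown sit.

Left open is how a chloro, a methoxy or an amine in the same place would compare with compound 2. Also open, on these data alone, is how far past its limit compound 3 lies.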